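This account rests on a few compounds, and the source may have more. Where it says the series, first, only, none or still open, it means among the compounds named here.

Measured in a functional assay on DU-145 cells (Homo sapiens) for cytotoxicity, read by MTT assay, with a stated time of 72 h; a lower number here means a stronger inhibitor, a higher number a weaker inhibitor:
- compound 1 `CC(C)(C)NC(=S)N/N=C1\CC(c2ccc(O)cc2)Oc2cc(O)ccc21`: 42900 nM
- compound 2 `Oc1ccc(C2C/C(=N\NC(=S)N3CCCC3)c3ccc(O)cc3O2)cc1`: 51700 nM
- compound 3 `CCCCNC(=S)N/N=C1\CC(c2ccc(O)cc2)Oc2cc(O)ccc21`: 57700 nM

Compound 3 is not separated from the other two, with a 1.3-fold higher number from compound 1 to compound 3 (0.13 log units; within the scatter) and a 1.1-fold higher number from compound 2 to compound 3 (0.05 log units; within the scatter). The change to compound 4 `Oc1ccc(C2C/C(=N\NC(=S)N3CCCCC3)c3ccc(O)cc3O2)cc1` is piperidin-1-yl in place of butylamino on a thiocarbonyl carbon. The closest measured exchanges on this carbon are a 1.1-fold higher number from compound 2 to compound 3 (0.05 log units; within the scatter), between butylamino and pyrrolidin-1-yl, and a 1.2-fold higher number from compound 1 to compound 2 (0.08 log units; within the scatter), between (tert-butyl)amino and pyrrolidin-1-yl. Both stayed within the scatter, so no step beyond the scatter is expected in this assay. The estimated step is a 1.2-fold lower number from compound 3 to compound 4 (0.06 log units; within the scatter). For compound 4 the expected value is 50000 nM, with an estimated range of 28000 nM to 90000 nM.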

Compound 4, half-maximal inhibitory concentration: 55300 nM
Compound 4: middle estimate off by 1.1-fold (0.04 log units), on the low side, within the range that was stated.
By their numbers in this assay, from the lowest: compounds 1, 2, 4 and 3 (each within the scatter of the next).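

In this assay, piperidin-1-yl on a thiocarbonyl carbon is not separated from the other three groups: a 1.0-fold lower number from compound 3 to compound 4 (0.02 log units; within the scatter), a 1.1-fold higher number from compound 2 to compound 4 (0.03 log units; within the scatter) and a 1.3-fold higher number from compound 1 to compound 4 (0.11 log units; within the scatter). A six-membered non-aromatic ring therefore reads like pyrrolidin-1-yl and the open-chain butylamino and (tert-butyl)amino, with no step beyond the scatter. Nothing available explains why these groups read alike. Still open, on these data alone, is whether a phenyl ring, a carboxylic acid or a morpholine ring on this carbon would give a step beyond the scatter.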